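Compound 2 to compound 3: iodo replaces benzofuranyl

The compounds below may be only part of what the source reports. "The series", "measured", "known", "first", "only" and "open" are said of these compounds alone.

In a functional assay on HepG2 cells (Homo sapiens) for antiproliferative activity, read by XTT assay, with a stated time of 72 h (a lower number here means a stronger inhibitor, a higher number a weaker inhibitor), compound 1 `CNc1ncnc2c1c(-c1ccoc1)cn2[C@@H]1O[C@H](CO)[C@@H](O)[C@H]1O` gives > 20000 nM, which is a limit. Compound 2 `CNc1ncnc2c1c(-c1cc3ccccc3o1)cn2[C@@H]1O[C@H](CO)[C@@H](O)[C@H]1O` gives > 20000 nM, also a limit. Going by the values given here, the only measured step is a step that the two limits leave unreadable from compound 1 to compound 2. Among the compounds with values here, the series so far amounts to the limit of > 20000 nM in this assay, at which 2 of the 2 values shown sit. Compound 2 therefore stands at a limit and offers no number to start from.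

Compound 3 `CNc1ncnc2c1c(I)cn2[C@@H]1O[C@H](CO)[C@@H](O)[C@H]1O` carries iodo in place of 1-benzofuran-2-yl on an aromatic carbon. Within the data shown here, the one measured step exchanged one ring-bearing group for another, whereas here the ring-bearing group leaves for a single atom, so that step gives no size to carry over. A modest gain in this assay is tentatively expected, though another limit remains likely. The expected change is an at least 1.6-fold lower number from compound 2 to compound 3 (0.22 log units; that floor lies within the scatter). Compound 3 is estimated at 12000 nM, with an expected range of 2000 nM to 20000 nM.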

Compound 3, half-maximal inhibitory concentration: > 20000 nM
Compound 3: only a limit was reported; the forecaster's own chance of this, stated with the estimate: 60%; middle value at least 1.6-fold (0.22 log units) from the limit.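

In this assay compound 3 gives > 20000 nM, a limit. The steps among compound 1, compound 2 and compound 3 cannot be read, and the series rests on one figure: the limit of > 20000 nM in this assay, at which 3 of the 3 values shown sit.

As far as these compounds go, whether furan-3-yl, 1-benzofuran-2-yl and iodo differ at all on the shared core remains open.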